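A Methoxy Group Added to Compound 2

The compounds below may be only part of what the source reports. "The series", "measured", "known", "first", "only" and "open" are said of these compounds alone.

In an ADME assay on L929 cells (Mus musculus) for cytotoxicity, read by resazurin assay, with a stated time of 72 h (a higher number here means a weaker inhibitor, a lower number a stronger inhibitor), compound 1 (`O=C(/C=C/c1ccc2c(c1)B(O)OC2)c1ccc(Br)cc1`) gives > 10 ug/mL as a limit, not a number. Compound 2 (`Nc1ccc(C(=O)/C=C/c2ccc3c(c2)B(O)OC3)cc1`) gives > 10 ug/mL as a limit too. Compound 3 (`Cn1cccc1C(=O)/C=C/c1ccc2c(c1)B(O)OC2`) gives > 10 ug/mL as a limit as well. All three sit at the same ceiling (the limit of > 10 ug/mL in this assay, at which 3 of the 3 values shown sit). The measured steps therefore offer no size to work from: a step that the two limits leave unreadable from compound 1 to compound 2 and a step that the two limits leave unreadable from compound 1 to compound 3 and a step that the two limits leave unreadable from compound 2 to compound 3 all stay unreadable. Compound 4 (`COc1cc(C(=O)/C=C/c2ccc3c(c2)B(O)OC3)ccc1N`) carries one change from compound 2 (methoxy in place of hydrogen on an aromatic carbon): methoxy in place of hydrogen on an aromatic carbon, ortho to an amino group. Among the compounds with values here, no measured step tests this change. The estimated step (a step that the limit leaves unreadable from compound 2 to compound 4) is expected to show no direction beyond the scatter. In this assay compound 4 is expected near 15 ug/mL, within an estimated range of 6 ug/mL to 40 ug/mL and quite possibly again at a limit.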

Compound 4, half-maximal inhibitory concentration: 1.45 ug/mL
Compound 4: the middle estimate sits 10-fold (1.01 log units) above what was measured; measured number below the stated range.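

In this assay, the steps among the three earlier compounds could not be read, so none of them showed that any change moves this number. Methoxy in place of hydrogen on this aromatic carbon, ortho to an amino group, gives the first readable step: an at least 6.8-fold lower number from compound 2 to compound 4 (0.83 log units; beyond the scatter). That size is only a minimum, since compound 2 sits at a limit: the limit of > 10 ug/mL in this assay, at which 3 of the 4 values shown sit.

Going by these compounds, what an ethoxy or a hydroxyl group would do on this same carbon stays open. So does whether methoxy would have the same effect on a ring without the amino group.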